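The compounds below may be only part of what the source reports. "The series", "measured", "known", "first", "only" and "open" are said of these compounds alone.

Measured compounds:
Compound 1 `Clc1ccc(-c2cc(-c3ccoc3)cc(-c3ccco3)n2)s1`: in an assay on isolated protein for inhibition of DNA topoisomerase 1 (Homo sapiens), with a stated time of 30 min, tested at 100 uM (a higher number here means more inhibition at the concentration tested (going by the name of the read-out), a lower number less inhibition), compound 1 gives 9.6%.
Compound 2 `Cc1ccc(-c2cc(-c3ccoc3)cc(-c3ccc(Cl)s3)n2)cc1`: compound 2 gives 0%.
Compound 3 `Clc1ccc(-c2cc(-c3ccco3)nc(-c3ccc(Cl)s3)c2)o1`: compound 3 gives 23.1%.

Among these three numbers compound 3 stands highest; compound 1 comes nearest to it, and compound 2 lies furthest away. Compound 4 `Cc1ccc(-c2cc(-c3ccc(Cl)o3)cc(-c3ccc(Cl)s3)n2)cc1` differs from compound 3 in one place: 4-methylphenyl in place of furan-2-yl on an aromatic carbon. For the measured compounds named here, one measured step bears on this change, namely a number 9.6 percentage points lower from compound 1 to compound 2 (within the scatter). That step was the same replacement on the shared core, and it shifted the number only within the scatter. The step from compound 3 to compound 4 is therefore expected to be small, at most a slight fall, a number 8.1 percentage points lower from compound 3 to compound 4 (within the scatter). Compound 4 is estimated at 15%, with a range from 2% to 28%.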

Compound 4, a percentage reported as inhibition, at one concentration (the size of the read-out at that concentration, not a potency): 14.2%
Compound 4: the middle estimate sits 0.8 percentage points above what was measured, and the stated range covers the measured number.
By their numbers in this assay, from the lowest: compounds 2, 1, 4 and 3 (each within the scatter of the next, the first and the last beyond it).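

Replacing furan-2-yl with 4-methylphenyl next to the ring nitrogen gave a number 8.9 percentage points lower from compound 3 to compound 4 (within the scatter), so the small effect seen earlier recurs on a second core: the same change on two cores in this assay, a number 9.6 percentage points lower (within the scatter) from compound 1 to compound 2 and a number 8.9 percentage points lower (within the scatter) from compound 3 to compound 4, 0.7 percentage points apart, within the scatter of two such steps The replacement of furan-3-yl with 5-chlorofuran-2-yl gave a number 14.2 percentage points higher from compound 2 to compound 4 (beyond the scatter), so its gain also carries over to a second core: the same change on two cores in this assay, a number 13.5 percentage points higher (beyond the scatter) from compound 1 to compound 3 and a number 14.2 percentage points higher (beyond the scatter) from compound 2 to compound 4, 0.7 percentage points apart, within the scatter of two such steps Across these four compounds, each change has much the same effect whichever form of the other position is present. From the compounds shown here alone, how an amine, a carboxylic acid or a longer chain at this position would affect the inhibition in this assay remains open. These single-concentration readings also leave open how potent any of the compounds is.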